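A few compounds are considered here, and "the series" means these few. Any claim that something is new, unique, unknown or untested is made for them only; others in the source may bear on it.

Four close relatives are compared here. Compound 1 `CN1c2ccc(NC(=S)Nc3ccc([N+](=O)[O-])cc3)cc2C(C)(C)C(=O)C1(C)C` carries a nitro group, and compound 2 `CN1c2ccc(NC(=S)Nc3ccc(C(F)(F)F)cc3)cc2C(C)(C)C(=O)C1(C)C` has the same core with a trifluoromethyl in its place. Compound 3 `CN1c2ccc(NC(=S)Nc3ccc([N+](=O)[O-])cc3)cc2C(C)(C)C(O)C1(C)C` keeps the nitro group on a changed core, and compound 4 `CN1c2ccc(NC(=S)Nc3ccc(C(F)(F)F)cc3)cc2C(C)(C)C(O)C1(C)C` pairs that changed core with the trifluoromethyl. How the core of compound 3 differs from the core of compound 1 is not broken down here.

In a functional assay on A2780 cells (Homo sapiens) for inhibition, with a stated time of 72 h (a lower number here means a stronger inhibitor, a higher number a weaker inhibitor), compound 1 gives 4400 nM, and compound 2 gives 3900 nM. The change between them is trifluoromethyl in place of nitro on an aromatic carbon, and it made a 1.1-fold lower number from compound 1 to compound 2 (0.05 log units; within the scatter), so the two numbers cannot be told apart. In this assay compound 3 gives 10000 nM, the highest of the three numbers, beyond the scatter from both others.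

Compound 4 has not been measured. The change from compound 3 to compound 4 is trifluoromethyl in place of nitro on an aromatic carbon, the same change as the one seen before, made at the same place. That earlier change made a 1.1-fold lower number from compound 1 to compound 2 (0.05 log units; within the scatter). The step expected from repeating it on the core of compound 3 is a 1.1-fold lower number from compound 3 to compound 4 (0.05 log units; within the scatter), resting only on that single precedent. For compound 4 in this assay the estimate is 9000 nM, expected to lie between 4000 nM and 20000 nM.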

Compound 4, half-maximal inhibitory concentration: 7600 nM
For compound 4 the middle estimate is 1.2-fold (0.07 log units) above the measured one; the measured number falls inside the stated range.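

In this assay, putting trifluoromethyl in place of nitro on the core of compound 3 gave a 1.3-fold lower number from compound 3 to compound 4 (0.12 log units; within the scatter), so the two numbers cannot be told apart. Within the data shown here, the same swap on the core of compound 1 also made no readable difference, and the two steps agree: the same change on two cores in this assay, a 1.1-fold lower number (0.05 log units; within the scatter) from compound 1 to compound 2 and a 1.3-fold lower number (0.12 log units; within the scatter) from compound 3 to compound 4, 1.2-fold (0.07 log units) apart, within the scatter of two such steps This shows that, in these two pairs, the swap can be carried from one core to the other without a detectable shift in the number; it does not show that the same would hold on any further core or in any other assay, and with only two pairs, each within the scatter, it gives no real size for the effect of the swap.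

The compounds shown leave open how the number would respond to a very different group in the same place on the ring, such as an amine or a carboxylic acid. They also leave open what a plain hydrogen there would give on either core.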